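This account rests on a few compounds, and the source may have more. Where it says the series, first, only, none or still open, it means among the compounds named here.

In a functional assay on NCI-H460 cells (Homo sapiens) for cytotoxicity, read by MTT assay, with a stated time of 72 h (a lower number here means a stronger inhibitor, a higher number a weaker inhibitor), compound 2 `Cc1ccc(S(=O)(=O)n2cc(COC3=C/C(=N\c4ccc(Br)cc4)c4ccccc4C3=O)nn2)cc1` gives 9410 nM and stands within the scatter of both compound 1 `Cc1ccc(S(=O)(=O)n2cc(COC3=C/C(=N\c4ccccc4)c4ccccc4C3=O)nn2)cc1` at 7220 nM and compound 3 `COc1ccc(/N=C2\C=C(OCc3cn(S(=O)(=O)c4ccc(C)cc4)nn3)C(=O)c3ccccc32)cc1` at 8390 nM on these numbers. Compound 4 `Cc1ccc(S(=O)(=O)n2cc(COC3=C/C(=N\c4ccc(Cl)cc4)c4ccccc4C3=O)nn2)cc1` departs from compound 2 by one exchange: chloro in place of bromo on an aromatic carbon (chloro in place of bromo on an aromatic carbon, para to a large group). Three measured steps at this place bear on it: a 1.3-fold higher number from compound 1 to compound 2 (0.12 log units; within the scatter) for bromo in place of hydrogen, a 1.2-fold higher number from compound 1 to compound 3 (0.07 log units; within the scatter) for methoxy in place of hydrogen and a 1.1-fold lower number from compound 2 to compound 3 (0.05 log units; within the scatter) for methoxy in place of bromo. None of them leaves the scatter, so the estimated 1.1-fold lower number from compound 2 to compound 4 (0.05 log units; within the scatter) is likewise expected to stay inside it, in no particular direction. Compound 4 is expected at 8300 nM within a range of 4800 nM to 14000 nM in this assay once measured.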

Compound 4, half-maximal inhibitory concentration: 12100 nM
The estimate for compound 4 lay 1.5-fold (0.16 log units) below the measured number; the range from low to high includes it.
By their numbers in this assay, from the lowest: compounds 1, 3, 2 and 4 (each within the scatter of the next).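

In this assay, chloro at this position stays within the scatter of each of the other three groups: against bromo (a 1.3-fold higher number from compound 2 to compound 4 (0.11 log units; within the scatter)), against methoxy (a 1.4-fold higher number from compound 3 to compound 4 (0.16 log units; within the scatter)) and against hydrogen (a 1.7-fold higher number from compound 1 to compound 4 (0.22 log units; within the scatter)). Even the largest of these steps, chloro in place of hydrogen, does not leave the scatter, so these four groups cannot be told apart here. Nothing given here accounts for these numbers. From the compounds shown here alone, whether an amine or a carboxylic acid at this position would move the number beyond the scatter remains open, as does the effect of changes elsewhere on the shared core.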